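The source may hold more compounds than are shown below. What is called first, only, known or untested is meant among the compounds shown, and "the series" means these compounds.

For the measured compounds named here, compound 1, `CCOC(COC(N)=O)C1=C(N2CC2)C(=O)C(C)=C(N2CC2)C1=O`, gives the higher of the two numbers measured so far in a functional assay on L1210 cells (Mus musculus), with a stated time of 1 days; on this read-out lower numbers stand for lower potency and higher numbers for higher potency (the scale is a negative logarithm): compound 1 shows 5.53, while compound 2, `CC1=C(N2CC2)C(=O)C(CCC(=O)N(C)C)=C(N2CC2)C1=O`, gives 5.09, a gap between the two that lies beyond the usual scatter of repeated measurements of this kind. Compound 2 differs from compound 1 in more than one place, so its lower number is recorded here without further comment.

Compound 3, `COCCOC(COC(N)=O)C1=C(N2CC2)C(=O)C(C)=C(N2CC2)C1=O`, is the one still to be measured, and it differs from compound 1 in a single place: methoxy in place of hydrogen on a saturated chain carbon, two bonds along the chain from an oxygen on a saturated carbon. The change leaves the shared core and both of its three-membered nitrogen rings untouched and only lengthens the chain on the saturated carbon, so it is expected to move the number in this assay little, with the step from compound 1 to compound 3 estimated at a number 0.13 log units lower from compound 1 to compound 3 (within the scatter), a step not beyond the scatter in either direction. Compound 3 is therefore expected to give 5.4 in this assay, with the true number estimated to fall between 4.9 and 5.9.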

Compound 3, logarithm of the reciprocal of the active concentration, log(1/C): 5.45
Beside the measured number, compound 3's estimate is 0.05 log units below it; measured number inside the range.
By their numbers in this assay, from the lowest: compound 2; then compounds 3 and 1 (each within the scatter of the next).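

The only comparison among the compounds shown that differs in one place reads, in this assay, a number 0.08 log units lower from compound 1 to compound 3 (within the scatter), and it corresponds to ethoxy becoming 2-methoxyethoxy with the shared core and everything else left as it was. This shows that, at this position on the chain, methoxy can take the place of hydrogen with no difference that can be told from the usual scatter of repeated measurements, which compounds 1 and 2 could not show, since they differ in more than one place. No further measurement is available to explain this result.

What the compounds shown leave open is whether a hydroxyl, an amine or a carboxylic acid in place of this methoxy, or a longer chain carrying further ether oxygens, would also keep the number within the scatter of compound 1. A single step also cannot say whether methoxy in place of hydrogen would give a similar result at any other place on the chain or in a compound with a different substituent on the shared core.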